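This account rests on a few compounds, and the source may have more. Where it says the series, first, only, none or still open, it means among the compounds named here.

Measured compounds and their values:

Compound 1 `CCN(CC)c1ccc(C(F)(F)F)cc1NC(=O)c1cccnc1`: "not active" (no number reported)
Compound 2 `O=C(Nc1cc(C(F)(F)F)ccc1Nc1ccc(Br)cc1)c1ccccc1`: 33800 nM
Compound 3 `O=C(Nc1cc(C(F)(F)F)ccc1N1CCCCC1)c1ccccc1`: "not active" (no number reported)

All three were tested in a functional assay on Jurkat cells (Homo sapiens) for cytotoxicity, read by MTT assay, with a stated time of 48 h; a lower number here means a stronger inhibitor, a higher number a weaker inhibitor. Compound 2 is the only one of the three to give a number, and in this assay compound 2 gives 33800 nM, a weak result. Among the compounds with values here, compound 1 gives "not active" (no number reported), and compound 3 also gives "not active" (no number reported); neither has a single number, so compound 3 stands with one further compound at the inactive end of what has been measured, and no step between measured compounds is available to lean on.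

Compound 4 `CCN(CC)c1ccc(C(F)(F)F)cc1NC(=O)c1ccccc1` differs from compound 3 in one place: diethylamino in place of piperidin-1-yl on an aromatic carbon. Compound 1 already carries the same diethylamino group on an aromatic carbon and shows no activity, and the shared core of compound 3 shows none either. The step from compound 3 to compound 4 is therefore expected to be small or none beyond the scatter, most likely leaving compound 4 without a reportable number. The estimate for compound 4 in this assay is 60000 nM, with a range from 20000 nM to 200000 nM.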

Compound 4, half-maximal inhibitory concentration: "not active" (no number reported)
No number was reported for compound 4, so the estimate cannot be set against anything.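

Neither compound 3 nor compound 4 gives a number, so no step can be read from this exchange of piperidin-1-yl for diethylamino. No measured evidence bears on this result. Left open is whether these two groups differ at all in activity, as both compounds lack a number to compare.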